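The source may report more compounds than this note shows. Statements on the series, on what has been measured and on what is new or still open speak of the compounds shown alone.

Measured so far:
- compound 1 `Cc1cc(NC(=O)Nc2ncccc2C)c2ccccc2n1`: in an ADME assay on HEK293 cells (Homo sapiens) for cytotoxicity, with a stated time of 72 h (a lower number here means that less compound is needed, a higher number that more compound is needed for the effect), compound 1 gives > 25000 nM, a limit rather than a number.
- compound 2 `Cc1ccc(NC(=O)Nc2cc(C)nc3ccccc23)cc1`: in this assay compound 2 gives > 25000 nM, likewise a limit.

Compound 2 therefore stands at the limit of > 25000 nM in this assay, at which 2 of the 2 values shown sit, with no number of its own. Among the compounds with values here, the one measured step, a step that the two limits leave unreadable from compound 1 to compound 2, is unreadable and gives no guidance. Compound 3 `CCc1ccc(NC(=O)Nc2cc(C)nc3ccccc23)cc1` differs from compound 2 by methyl in place of hydrogen on a saturated chain carbon bound to an aromatic carbon. Within the data shown here, no measured step bears on this change, so no shift beyond the scatter is expected in this assay. Compound 3 is expected to give 30000 nM, between 15000 nM and 100000 nM. The expected step is a step that the limit leaves unreadable from compound 2 to compound 3.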

Compound 3, half-maximal effective concentration: 16000 nM
Beside the measured number, compound 3's estimate is 1.9-fold (0.27 log units) above it; low and high end bracket the measured number.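

In this assay, within the data shown here, methyl to ethyl on a saturated chain carbon bound to an aromatic carbon gives an at least 1.5-fold lower number from compound 2 to compound 3 (0.19 log units; that floor lies within the scatter) and so provides the first step that can be read at all. Among these compounds, compound 3 is the only compound with a number of its own, while the others remain at a limit: the limit of > 25000 nM in this assay, at which 2 of the 3 values shown sit.

From the compounds shown here alone, the full size of this step stays open, with compound 2 held at a limit. Also open, going by these compounds, is whether a longer chain such as propyl, or an amine or a carboxylic acid at this place, would move the number further.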